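Swapping methoxy for trifluoromethyl on the quinoline-acid core

The compounds below may be only part of what the source reports. "The series", "measured", "known", "first", "only" and "open" are said of these compounds alone.

Of the compounds shown here, three sharing one core have been measured in a functional assay on A-375 cells (Homo sapiens) for antiproliferative activity, read by MTT assay, with a stated time of 24 h, tested at 11.11 ug/mL; on this read-out lower numbers stand for a weaker effect and higher numbers for a stronger effect at the one concentration tested. Compound 1 `Cc1c(C(=O)Nc2c(F)cc(-c3cccc(F)c3)cc2F)nc2ccc(F)cc2c1C(=O)O` gives 36.3%. Compound 2 `CCOc1ccc2nc(C(=O)Nc3c(F)cc(-c4cccc(F)c4)cc3F)c(C)c(C(=O)O)c2c1` gives 48.3%, and compound 3 `COc1ccc2nc(C(=O)Nc3c(F)cc(-c4cccc(F)c4)cc3F)c(C)c(C(=O)O)c2c1` gives 35.2%. Compound 3 thus gives the lowest of the three numbers, but one of the two steps that lead to it is a number 1.1 percentage points lower from compound 1 to compound 3 (within the scatter), so those two cannot be told apart, while the other is a number 13.1 percentage points lower from compound 2 to compound 3 (beyond the scatter).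

Compound 4 `Cc1c(C(=O)Nc2c(F)cc(-c3cccc(F)c3)cc2F)nc2ccc(C(F)(F)F)cc2c1C(=O)O` differs from compound 3 in one place: trifluoromethyl in place of methoxy on an aromatic carbon. The same position has already been changed twice. Replacing fluoro by methoxy gave a number 1.1 percentage points lower from compound 1 to compound 3 (within the scatter), whereas replacing fluoro by ethoxy gave a number 12 percentage points higher from compound 1 to compound 2 (beyond the scatter), and shortening ethoxy to methoxy gave a number 13.1 percentage points lower from compound 2 to compound 3 (beyond the scatter). The position therefore tolerates small changes with effects ranging from nothing to modest. For the measured compounds named here, no measured step involves trifluoromethyl, so the direction is open; a step of at most modest size is expected in this assay , most likely within the scatter.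

The estimated step from compound 3 to compound 4 is a number 2.8 percentage points higher from compound 3 to compound 4 (within the scatter). Compound 4 is therefore expected to give about 38%, with a range from 24% to 54%.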

Compound 4, a percentage reported as inhibition, at one concentration (the size of the read-out at that concentration, not a potency): 45.4%
The estimate for compound 4 lay 7.4 percentage points below the measured number; measured number inside the range.
By their numbers in this assay, from the lowest: compounds 3, 1, 4 and 2 (each within the scatter of the next, the first and the last beyond it).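

In this assay, for the compounds shown here, trifluoromethyl, which has no oxygen and no hydrogen-bond acceptor, is the first group at this position that is neither a halogen nor attached through oxygen, and putting it in place of methoxy gives a number 10.2 percentage points higher from compound 3 to compound 4 (beyond the scatter). Compared with the other two groups, the same change gives a number 2.9 percentage points lower from compound 2 to compound 4 (within the scatter) for ethoxy and a number 9.1 percentage points higher from compound 1 to compound 4 (within the scatter) for fluoro, so compound 4 cannot be told apart from either of those compounds, even though a number 12 percentage points higher from compound 1 to compound 2 (beyond the scatter). The oxygen of ethoxy is therefore not required for a number in the range of compound 2, since compound 4 reaches that range without any oxygen at this position, while methoxy in compound 3 stands apart from both of them.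

On these data alone, it remains open how a longer chain such as propoxy, or an amine or a nitrile, would behave at this position, and whether the order seen at one concentration would hold across a full range of concentrations. Nothing available here explains why these numbers differ at this position.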